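Sigma-1 Binding: A Benzofuran in Place of a Trifluoromethylphenyl

A few compounds are considered here, and "the series" means these few. Any claim that something is new, unique, unknown or untested is made for them only; others in the source may bear on it.

Of the compounds shown here, two have so far been measured in an assay on membranes from Cortex for displacement of a labelled ligand from Sigma non-opioid intracellular receptor 1 (Cavia porcellus), read by scintillation counting, with a stated time of 120 min; on this read-out lower numbers stand for stronger inhibition and higher numbers for weaker inhibition. Compound 1 `Fc1ccc(C(SCCNC2CCN(Cc3ccc(C(F)(F)F)cc3)CC2)c2ccc(F)cc2)cc1` gives 186 nM, and compound 2 `[O-][S+](CCNC1CCN(CC(O)Cc2ccccc2)CC1)C(c1ccc(F)cc1)c1ccc(F)cc1` gives 351 nM. Compound 1 thus has the lowest of the two numbers, but its nearest neighbour, compound 2, lies within the usual scatter of this assay, so the two values cannot be ordered with confidence. The account now turns to compound 3 `Fc1ccc(C(SCCNC2CCN(Cc3cc4ccccc4o3)CC2)c2ccc(F)cc2)cc1`, which has not yet been measured. Compound 3 differs from compound 1 in a single place: 1-benzofuran-2-yl in place of 4-(trifluoromethyl)phenyl on a saturated chain carbon bound to an amine nitrogen in a ring. Going by the values given here, no measured pair shows what this kind of change does on this read-out, so there is nothing beyond compound 1 itself to anchor the expectation. The step in this assay is expected to be small, with no clear direction, as written in a 1.2-fold lower number from compound 1 to compound 3 (0.07 log units; within the scatter). For compound 3 the inhibition constant is therefore estimated at 160 nM, with a range from 50 nM to 500 nM.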

Compound 3, inhibition constant: 205 nM
For compound 3 the middle estimate is 1.3-fold (0.11 log units) below the measured one; measured number inside the range.
By their numbers in this assay, from the lowest: compounds 1, 3 and 2 (each within the scatter of the next).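

In this assay the change at this place now has a first measured step, a 1.1-fold higher number from compound 1 to compound 3 (0.04 log units; within the scatter), so on a saturated chain carbon bound to an amine nitrogen in a ring the two groups cannot be told apart. This holds although 4-(trifluoromethyl)phenyl, with its one six-membered aromatic ring and three fluorine atoms, gives way to 1-benzofuran-2-yl, which brings a second, five-membered aromatic ring and one hydrogen-bond acceptor. This is one pair on one core, and no measurement at hand bears on why the two groups read alike.

As far as these compounds go, what a plain phenyl or a 1-benzothiophen-2-yl group would give at this place remains open. So does whether a longer chain carrying the same 1-benzofuran-2-yl group would keep the number in the same region.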